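The source may hold more compounds than are shown below. What is called first, only, known or untested is meant among the compounds shown, and "the series" means these compounds.

Compound 1 `O=C(Cn1c(=O)oc2cc(Cl)ccc21)NCc1cccs1` gives 53.6% in an ADME assay on RAW264.7 cells (Mus musculus) for cytotoxicity, read by MTT assay, with a stated time of 72 h, tested at 100 uM; a lower number here means a weaker effect, a higher number a stronger effect of the compound at the concentration tested. Compound 2 `O=C(Cn1c(=O)oc2cc([N+](=O)[O-])ccc21)NCc1cccs1` gives 41%. Compound 3 `O=C(Cn1c(=O)oc2cc([N+](=O)[O-])ccc21)NCc1ccccn1` gives 33.4%.

The three measured compounds share one core and differ at two places. Between compound 2 and compound 3 the difference is pyridin-2-yl in place of thiophen-2-yl on a saturated chain carbon bound to an amide-type nitrogen, and the step is a number 7.6 percentage points lower from compound 2 to compound 3 (within the scatter), so these two numbers cannot be told apart. Between compound 2 and compound 1 the difference is chloro in place of nitro on an aromatic carbon, and the step is a number 12.6 percentage points higher from compound 2 to compound 1 (beyond the scatter). Compound 3 stands lowest of the three, with compound 1 furthest from it and compound 2 nearest.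

Compound 4 `O=C(Cn1c(=O)oc2cc(Cl)ccc21)NCc1ccccn1` has not yet been measured in this assay. It differs from compound 3 by chloro in place of nitro on an aromatic carbon. Among the measured compounds shown here, this is the same change as the one from compound 2 to compound 1, made on the core that carries the pyridin-2-yl group instead of the thiophen-2-yl group, and the place of the change is described in the same words in both cases. For the measured compounds named here, since the one earlier instance of this change gave a number 12.6 percentage points higher from compound 2 to compound 1 (beyond the scatter), a step of similar size is expected from compound 3 to compound 4, namely a number 12.6 percentage points higher from compound 3 to compound 4 (beyond the scatter). This rests on a single pair, so the expectation carries the scatter of the method. Compound 4 is therefore estimated at 46%, within a range from 32% to 60%.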

Compound 4, a percentage reported as inhibition, at one concentration (the size of the read-out at that concentration, not a potency): 40%
Estimate against measurement, compound 4: 6 percentage points above; low and high end bracket the measured number.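

In this assay, chloro in place of nitro on an aromatic carbon gives a number 6.6 percentage points higher from compound 3 to compound 4 (within the scatter), and set beside its earlier instance this change reads: the same change on two cores in this assay, a number 12.6 percentage points higher (beyond the scatter) from compound 2 to compound 1 and a number 6.6 percentage points higher (within the scatter) from compound 3 to compound 4, 6 percentage points apart, within the scatter of two such steps. Pyridin-2-yl in place of thiophen-2-yl gives a number 13.6 percentage points lower from compound 1 to compound 4 (beyond the scatter), and set beside its earlier instance this change reads: the same change on two cores in this assay, a number 7.6 percentage points lower (within the scatter) from compound 2 to compound 3 and a number 13.6 percentage points lower (beyond the scatter) from compound 1 to compound 4, 6 percentage points apart, within the scatter of two such steps. Among the compounds shown here, each change therefore carries from one core to the other in these four compounds with no difference that can be told apart, but this does not show that the steps are equal in size, and with only two instances of each change it does not show that either would hold on any further core.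

The compounds shown leave open what other groups on that aromatic carbon, such as a methoxy group, an amine or a carboxylic acid, would give in this assay, and whether they would follow the same course on both cores. They also leave open what a phenyl ring in place of the thiophen-2-yl or pyridin-2-yl group, or a longer chain leading to that ring from the amide nitrogen, would do to the read-out.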